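Quinolone amides: bromo to trifluoromethoxy on the fused ring

The source may report more compounds than this note shows. Statements on the series, on what has been measured and on what is new or still open speak of the compounds shown alone.

Measured so far
compound 1, `Cc1c(C(=O)Nc2ccc(Oc3ncnc4[nH]cc(-c5ccccc5)c34)c(F)c2)c(=O)c2cc(Br)ccc2n1C`, 3120 nM
compound 2, `CCc1c(C(=O)Nc2ccc(Oc3ncnc4[nH]cc(-c5ccccc5)c34)c(F)c2)c(=O)c2cc(C)ccc2n1C`, 78 nM
compound 3, `CCc1ccc2c(c1)c(=O)c(C(=O)Nc1ccc(Oc3ccnc4[nH]cc(-c5ccccc5)c34)c(F)c1)c(C)n2C`, 30 nM

In an assay on isolated protein for inhibition of tyrosine-protein kinase receptor UFO (Homo sapiens), read by FRET and Z'-LYTE, with a stated time of 1.5 h (a lower number here means a stronger inhibitor, a higher number a weaker inhibitor), compound 1 gives 3120 nM, the highest of the three numbers. For the measured compounds named here, compound 2 sits at a markedly lower number in this assay, and compound 3 lower still, but each of those differs from compound 1 in more than one place, so neither pair isolates a single change, and no step has been measured one change at a time.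

Compound 4, `Cc1c(C(=O)Nc2ccc(Oc3ncnc4[nH]cc(-c5ccccc5)c34)c(F)c2)c(=O)c2cc(OC(F)(F)F)ccc2n1C`, keeps the whole of compound 1 apart from one exchange: trifluoromethoxy in place of bromo on an aromatic carbon. Going by the values given here, there is no measured pair to lean on for this exchange. Among the compounds with values here, compound 1 is the only member carrying bromo at that position, and it gives the weakest result, so the working assumption is that replacing the bromo is at least as likely to lower the number as to raise it. For compound 4 a small step toward a lower number is expected, a 2.1-fold lower number from compound 1 to compound 4 (0.32 log units; beyond the scatter), though one that may not reach beyond the scatter. Compound 4 is estimated at 1500 nM, within a range from 400 nM to 6000 nM, to be confirmed in this assay.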

Compound 4, half-maximal inhibitory concentration: 74 nM
The estimate for compound 4 lay 20-fold (1.31 log units) above the measured number, outside the stated range (below it).
By their numbers in this assay, from the lowest: compound 3; then compounds 4 and 2 (each within the scatter of the next); then compound 1.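

For the compounds shown here, this is the first step that can be read one change at a time, and it shows that the group on this aromatic carbon, meta to a fused ring and para to a fused ring, strongly affects the number in this assay: trifluoromethoxy in place of bromo gives a 42-fold lower number from compound 1 to compound 4 (1.62 log units; beyond the scatter). The exchange replaces a single bromine with a group of five heavy atoms that adds one hydrogen-bond acceptor, while the rest of compound 1 stays the same, so the position accepts the larger group and the bromo result alone did not show what this carbon allows. No measurement at hand indicates which feature of the exchange accounts for the step.

Going by these compounds alone, with only two groups compared directly at this carbon, it remains open whether chloro, methoxy, trifluoromethyl or an amine would give a number nearer to that of compound 4 or to that of compound 1. From the compounds shown here alone, compounds 2 and 3 each differ from compound 1 in more than one place, so their steps cannot be read, and it also remains open whether this exchange would have a similar effect on those other compounds.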